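Compound 3 at the Limit of the Growth Assay

A few compounds are considered here, and "the series" means these few. Any claim that something is new, unique, unknown or untested is made for them only; others in the source may bear on it.

Measured in a functional assay on MCF7 cells (Homo sapiens) for cytotoxicity, read by sulforhodamine B assay, with a stated time of 48 h, in the presence of a further agent that is not named here; on this read-out lower numbers stand for stronger inhibition of growth and higher numbers for weaker inhibition of growth:
- Compound 1 `COc1ccc(N/N=C/c2c(C)nn(-c3ccccc3)c2Oc2ccc(-c3nc4cc(C(N)=O)ccc4[nH]3)cc2)cc1`: > 100000 nM
- Compound 2 `Cc1nn(-c2ccccc2)c(Oc2ccc(-c3nc4cc(C(N)=O)ccc4[nH]3)cc2)c1/C=N/NC(N)=O`: > 100000 nM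

Both entries are limits of the assay, not numbers. In this assay compound 2 gives > 100000 nM, and this is a limit. Compound 1 shares that position, and the record for the pair reads: the limit of > 100000 nM in this assay, at which 2 of the 2 values shown sit.

The next compound is compound 3 `Cc1nn(-c2ccccc2)c(Oc2ccc(-c3nc4cc(C(N)=O)ccc4[nH]3)cc2)c1/C=N/NC(N)=S`, which differs from compound 2 at one place: a group of 3 heavy atoms (1 carbon, 1 nitrogen, 1 sulfur; no ring) in place of a group of 3 heavy atoms (1 carbon, 1 nitrogen, 1 oxygen; no ring), on an amine nitrogen. A group of 3 heavy atoms containing sulfur thus replaces carbamoyl on an amine nitrogen.

Within the data shown here, the only measured step that bears on this change is at the same amine nitrogen: a step that the two limits leave unreadable from compound 1 to compound 2. It gives no size to carry forward, so no step size can be derived from the measurements. Compound 2 provides only the limit > 100000 nM, and the expectation is that compound 3 remains weak in this assay, possibly also reported only as a limit. Any readable move could only be towards stronger inhibition. The estimated step is an at least 1.4-fold lower number from compound 2 to compound 3 (0.15 log units; that floor lies within the scatter). Compound 3 is expected at 70000 nM, with an estimated range from 10000 nM to 150000 nM.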

Compound 3, concentration for 50% growth inhibition: > 100000 nM
Compound 3 was reported as a limit; the forecaster's own chance of this, stated with the estimate: 55%; middle value at least 1.4-fold (0.15 log units) from the limit.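

In this assay compound 3 gives > 100000 nM, which is a limit and not a number. No step among compound 1, compound 2 and compound 3 can be read: the limit of > 100000 nM in this assay, at which 3 of the 3 values shown sit.

The compounds shown leave open whether any group on this amine nitrogen gives a readable value, and how far carbamoyl and the group containing sulfur differ.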